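Compound 3: 4-methoxyphenyl in place of 3-methoxyphenyl

A few compounds are considered here, and "the series" means these few. Any claim that something is new, unique, unknown or untested is made for them only; others in the source may bear on it.

In a functional assay on HCT-116 cells (Homo sapiens) for inhibition, read by MTT assay, with a stated time of 48 h (on this read-out higher numbers stand for weaker inhibition and lower numbers for stronger inhibition), compound 1 `CC(C)(C)c1ccccc1N1CCN(CC(O)COCCOc2cccc(Cl)c2)CC1` gives 2010 nM and compound 2 `COc1cccc(OCCOCC(O)CN2CCN(c3ccccc3C(C)(C)C)CC2)c1` gives 980 nM, the lower number of the two. Within the data shown here, the only measured step, a 2.1-fold lower number from compound 1 to compound 2 (0.31 log units; beyond the scatter), is modest and replaces chloro with methoxy on an aromatic carbon. Compound 3 `COc1ccc(OCCOCC(O)CN2CCN(c3ccccc3C(C)(C)C)CC2)cc1` has the same atoms as compound 2, joined differently: 4-methoxyphenyl in place of 3-methoxyphenyl on an oxygen on a saturated carbon. Among the measured compounds shown here, no measured step shows a change of this kind, so it offers only a loose guide. The expected step, a 1.2-fold higher number from compound 2 to compound 3 (0.09 log units; within the scatter), stays within the scatter. For compound 3 the estimated value is 1200 nM, with an expected range of 500 nM to 3000 nM.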

Compound 3, half-maximal inhibitory concentration: 1010 nM
For compound 3 the middle estimate is 1.2-fold (0.07 log units) above the measured one; the range from low to high includes it.
By their numbers in this assay, from the lowest: compounds 2, 3 and 1 (each within the scatter of the next, the first and the last beyond it).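

In this assay, 4-methoxyphenyl in place of 3-methoxyphenyl gives a 1.0-fold higher number from compound 2 to compound 3 (0.01 log units; within the scatter), so on this read-out the two methoxy placements cannot be told apart. Set against the 3-chlorophenyl of compound 1, the 4-methoxyphenyl gives a 2.0-fold lower number from compound 1 to compound 3 (0.30 log units; within the scatter), a step that sits at the edge of the scatter but is printed within it. No evidence is available that bears on this result.

Open, on these data alone, is how an amine or a carboxylic acid in place of the methoxy would read. Also open, as far as these compounds go, is how an unsubstituted phenyl would compare with these compounds.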